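The compounds below may be only part of what the source reports. "The series", "measured", "known", "first", "only" and "open" are said of these compounds alone.

Measured in a functional assay (blood) for inhibition, with Homo sapiens as the target; a lower number here means a stronger inhibitor, a higher number a weaker inhibitor:
Compound 1 `CC(C)(C)Sc1c(CC(C)(C)C(=O)O)n(Cc2ccc(Cl)cc2)c2ccc(OCc3cccc(Cl)n3)cc12`: 410 nM
Compound 2 `CC(COc1ccc2c(c1)c(SC(C)(C)C)c(CC(C)(C)C(=O)O)n2Cc1ccc(Cl)cc1)c1ccccn1`: 270 nM
Compound 3 `CC(C)(C)Sc1c(CC(C)(C)C(=O)O)n(Cc2ccc(Cl)cc2)c2ccc(OCc3cnccn3)cc12`: 400 nM

Compound 3 stands within the scatter of both other compounds, with a 1.0-fold lower number from compound 1 to compound 3 (0.01 log units; within the scatter) and a 1.5-fold higher number from compound 2 to compound 3 (0.17 log units; within the scatter). Compound 4 `CC(C)c1csc(COc2ccc3c(c2)c(SC(C)(C)C)c(CC(C)(C)C(=O)O)n3Cc2ccc(Cl)cc2)n1` carries 4-isopropyl-1,3-thiazol-2-yl in place of pyrazin-2-yl on a saturated chain carbon bound to an oxygen on an aromatic ring. All three measured steps change the group at this same place, and a 1.5-fold lower number from compound 1 to compound 2 (0.18 log units; within the scatter) is likewise small. None of them introduces the incoming group, so the evidence is only indirect. In this assay, no step beyond the scatter is therefore expected. The expected change is a 1.3-fold lower number from compound 3 to compound 4 (0.10 log units; within the scatter). For compound 4 the estimate is 320 nM, with an expected range from 130 nM to 750 nM.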

Compound 4, half-maximal inhibitory concentration: > 3000 nM
Compound 4 ended at the assay's limit; the forecaster's own chance of this, stated with the estimate: 3%; middle value at least 9.3-fold (0.97 log units) from the limit.
By their numbers in this assay, from the lowest: compounds 2, 3 and 1 (each within the scatter of the next). At a limit, above all of these: compound 4.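

In this assay compound 4 stands at a limit and not at a number: the limit of > 3000 nM in this assay, at which 1 of the 4 values shown sits. The place on a saturated chain carbon bound to an oxygen on an aromatic ring had taken 6-chloropyridin-2-yl, 1-(pyridin-2-yl)ethyl and pyrazin-2-yl with every step within the scatter, but it does not tolerate every group: 4-isopropyl-1,3-thiazol-2-yl gives an at least 7.5-fold higher number from compound 3 to compound 4 (0.87 log units; beyond the scatter), an at least 11-fold higher number from compound 2 to compound 4 (1.04 log units; beyond the scatter) and an at least 7.3-fold higher number from compound 1 to compound 4 (0.86 log units; beyond the scatter).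

The compounds shown leave open whether this step goes with the five-membered ring or with its isopropyl group. An unsubstituted 1,3-thiazol-2-yl, or a 4-methyl-1,3-thiazol-2-yl, would separate the two.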